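Dichlorine on the benzyl arm of compound 2

The source may hold more compounds than are shown below. What is called first, only, known or untested is meant among the compounds shown, and "the series" means these compounds.

Compound 2 `C(=N/OCc1ccccc1)\c1c(-c2ccc3ccccc3c2)nc2occn12` gives 840 nM in an assay on HepG2 cells for agonist activity at nuclear receptor subfamily 1 group I member 3 (Homo sapiens), read by a luciferase reporter, with a stated time of 23 h (a lower number here means that less compound is needed, a higher number that more compound is needed for the effect), the lowest of the two numbers measured; compound 1 `COc1ccc(CO/N=C/c2c(-c3ccc4ccccc4c3)nc3occn23)cc1` gives 4400 nM. Going by the values given here, the only measured step, a 5.2-fold lower number from compound 1 to compound 2 (0.72 log units; beyond the scatter), concerns hydrogen in place of methoxy on an aromatic carbon. Compound 3 `Clc1ccc(CO/N=C/c2c(-c3ccc4ccccc4c3)nc3occn23)c(Cl)c1` differs from compound 2 by 2,4-dichlorophenyl in place of phenyl on a saturated chain carbon bound to an oxygen. Among the compounds with values here, no measured step adds chlorine, so the evidence bears only loosely on this change. For compound 3 a step of a 1.4-fold lower number from compound 2 to compound 3 (0.15 log units; within the scatter) is expected, within or just beyond the scatter, and its value in this assay is estimated at 600 nM, between 150 nM and 2500 nM.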

Compound 3, half-maximal effective concentration: 1500 nM
Beside the measured number, compound 3's estimate is 2.5-fold (0.40 log units) below it, and the stated range covers the measured number.
By their numbers in this assay, from the lowest: compounds 2 and 3 (each within the scatter of the next); then compound 1.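

At this saturated chain carbon bound to an oxygen, 2,4-dichlorophenyl in place of phenyl gives a 1.8-fold higher number from compound 2 to compound 3 (0.25 log units; within the scatter) and so the ring can carry two chlorine atoms without a reading in this assay that stands apart from the unsubstituted one. In place of 4-methoxyphenyl, the same group gives a 2.9-fold lower number from compound 1 to compound 3 (0.47 log units; beyond the scatter) and so the two substituted rings do not read alike. Nothing measured here explains either step.

As far as these compounds go, whether a single chlorine would read the same remains open. So does the effect of an amine or a carboxylic acid on this ring, or of a longer chain leading to it.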